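The source may report more compounds than this note shows. Statements on the series, on what has been measured and on what is new or still open speak of the compounds shown alone.

Compound 1 `C/C(=N\O)c1ccc2[nH]c(-c3ccc(Cl)cc3)nc2c1`, compound 2 `C/C(=N\NC(N)=O)c1ccc2[nH]c(-c3ccc(Cl)cc3)nc2c1` and compound 3 `C/C(=N\NC(N)=S)c1ccc2[nH]c(-c3ccc(Cl)cc3)nc2c1` share a core and differ in one group. In an ADME assay on Vero cells (Chlorocebus sabaeus) for cytotoxicity, read by MTT assay, with a stated time of 96 h (a lower number here means that less compound is tolerated, a higher number that more compound is tolerated), compound 1 gives "not determined" (no result reported), so it offers no guidance here. Compound 2 gives > 100000 nM, which is a limit of the assay and not a number. Compound 3 gives > 100000 nM, again only a limit. Compound 3 therefore has no exact value and stands at the limit of > 100000 nM in this assay, at which 2 of the 3 values shown sit.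

Compound 4 `C/C(=N\NC(N)=S)c1ccc2[nH]c(-c3ccoc3)nc2c1` keeps the rest of compound 3 and changes one group: furan-3-yl in place of 4-chlorophenyl on an aromatic carbon, with furan-3-yl in place of 4-chlorophenyl on an aromatic carbon. Going by the values given here, the only measured step is a step that the two limits leave unreadable from compound 2 to compound 3. It gives no size to carry forward, and it concerns a different place on the molecule. Among the compounds with values here, no measured step covers this exchange of rings.

With no evidence for a shift in either direction, this assay is expected to show no change beyond the scatter, and the estimated step is a number no higher from compound 3 to compound 4 (the limit leaves the size open). For compound 4 the estimate is 100000 nM, with an expected range of 40000 nM to 200000 nM.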

Compound 4, half-maximal cytotoxic concentration: 100000 nM
Beside the measured number, compound 4's estimate shows no gap at the digits printed; the measured number falls inside the stated range.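

In this assay compound 4 gives 100000 nM, the only exact number among the compounds shown, so with furan-3-yl on this aromatic carbon the read-out reaches a measurable value. Compound 3 gives > 100000 nM, which is a limit of the assay and not a number. Replacing 4-chlorophenyl with furan-3-yl gives a number no higher from compound 3 to compound 4 (the limit leaves the size open), and the earlier step cannot be read either. The comparison therefore stays at the top of what the assay can report: the limit of > 100000 nM in this assay, at which 2 of the 4 values shown sit.

Still open, as far as these compounds go, is whether another group on this aromatic carbon, such as an amine, a carboxylic acid or a simple methyl, would give a clearly lower value. Also open, from the compounds shown here alone, is whether furan-3-yl would give a similar reading with the side chain of compound 1 or compound 2.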